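Swapping Methoxy for Methyl on a Weakly Active Scaffold

The compounds below may be only part of what the source reports. "The series", "measured", "known", "first", "only" and "open" are said of these compounds alone.

Compound 1 `COc1ccc(-c2cn(C[C@H]3c4c(ccc(O)c4C)[C@@H]4CC[C@@]5(C)C[C@]43CC5=O)nn2)cc1` was tested in a functional assay on MCF7 cells (Homo sapiens) for cytotoxicity, read by MTT assay, with a stated time of 4 days (on this read-out higher numbers stand for weaker inhibition and lower numbers for stronger inhibition), and returned only a limit, > 20000 nM, rather than a number. Two related compounds were run as well. Compound 2 `C=C1C[C@]23C[C@@]1(O)CC[C@@H]2c1cccc(C)c1[C@@H]3Cn1cc(-c2ccccc2)nn1` likewise reached only the limit of this assay, > 20000 nM. Compound 3 `C=C1C[C@]23C[C@@]1(O)CC[C@H]2c1cc(Br)c(O)c(C)c1[C@@H]3Cn1cc(-c2ccc(F)cc2)nn1` gave a measured value in this assay of 19200 nM. So compound 1 stands at the limit of > 20000 nM in this assay, at which 2 of the 3 values shown sit, with no numerical value to rank it. Compound 4 `Cc1ccc(-c2cn(C[C@H]3c4c(ccc(O)c4C)[C@@H]4CC[C@@]5(C)C[C@]43CC5=O)nn2)cc1` keeps the shared core of compound 1 and differs in one place: methyl in place of methoxy on an aromatic carbon. Among the measured compounds shown here, no measured pair isolates this change, so no step is known from it. For compound 4 the expected step is a step that the limit leaves unreadable from compound 1 to compound 4, within the scatter. Compound 4 is estimated at 25000 nM, ranging from 10000 nM to 60000 nM, most likely again only a limit.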

Compound 4, half-maximal inhibitory concentration: > 20000 nM
Compound 4: a limit, no number; the forecaster's own chance of this, stated with the estimate: 80%; the middle value does not contradict the limit.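

Compound 1 and compound 4 both give only a limit in this assay, so no step can be read between them: the limit of > 20000 nM in this assay, at which 3 of the 4 values shown sit.

The compounds shown leave open how 4-methoxyphenyl and 4-methylphenyl truly compare on the shared core.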